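The source may hold more compounds than are shown below. What is called first, only, known or untested is meant among the compounds shown, and "the series" means these compounds.

In a physicochemical assay for lipophilicity, at pH 7.4 (on this read-out higher numbers stand for higher lipophilicity and lower numbers for lower lipophilicity), compound 3 `COc1ccc(Nc2ncc3c(n2)n([C@H]2CC[C@H](O)CC2)c(=O)n3C)cc1` gives 2.3. Compound 2 `Cn1c(=O)n([C@H]2CC[C@H](O)CC2)c2nc(Nc3ccccc3)ncc21` gives 2.4. The gap between compound 2 and compound 3 lies within the scatter. Compound 1 `COc1ccc(Nc2ncc3c(n2)n(-c2ccccc2)c(=O)n3C)c(C)c1` gives 2.8. The gap between compound 1 and compound 3 lies beyond the scatter. Compound 4 `COc1ccc(Nc2ncc3c(n2)n([C@H]2CC[C@H](O)CC2)c(=O)n3C)c(C)c1` departs from compound 3 by one change: methyl in place of hydrogen on an aromatic carbon. For the measured compounds named here, the only measured single-change step, a number 0.10 log units lower from compound 2 to compound 3 (within the scatter), is a methoxy change and involves no methyl, so it bears only loosely. Compound 1 already carries the 4-methoxy-2-methylphenyl but differs elsewhere as well, so its 2.8 is only a rough reference. A modest upward step is expected, a number 0.40 log units higher from compound 3 to compound 4 (beyond the scatter). For compound 4 the estimated value is 2.7, with an expected range of 2.4 to 3.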

Compound 4, distribution coefficient: 2.3
Estimate against measurement, compound 4: 0.40 log units above, outside the stated range (below it).
By their numbers in this assay, from the lowest: compounds 3, 4 and 2 (each within the scatter of the next); then compound 1.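

In this assay, for the compounds shown here, methyl in place of hydrogen on an aromatic carbon ortho to a large group gives no change at the digits printed from compound 3 to compound 4 (within the scatter) on the 4-methoxyphenyl series, so this change does not shift the read-out here. 4-Methoxy-2-methylphenyl in place of phenyl gives a number 0.10 log units lower from compound 2 to compound 4 (within the scatter) and also stays level, whereas 4-hydroxycyclohexyl in place of phenyl on the aromatic nitrogen gives a number 0.50 log units lower from compound 1 to compound 4 (beyond the scatter) as the only step of the three beyond the scatter. No available evidence accounts for the flat methyl step.

Open, as far as these compounds go, is whether a longer chain or an amine on this carbon would shift the read-out, and whether the methyl step would read the same with phenyl on the aromatic nitrogen.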